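Working notes: hydroxymethyl for isopropyl on compound 1

The source may report more compounds than this note shows. Statements on the series, on what has been measured and on what is new or still open speak of the compounds shown alone.

Measured so far:
compound 1, `CCN(Cc1cccs1)C(=O)COc1ccc(C(C)C)cc1`: 397 nM
compound 2, `Cc1ccc(OCC(=O)N(Cc2cccs2)c2c[nH]nc2C)cc1`: 0.4 nM

Going by the values given here, in an assay on HEK293 cells for agonist activity at transient receptor potential cation channel subfamily M member 8 (Homo sapiens), read by fluorescence and calcium flux, with a stated time of 15 min (on this read-out lower numbers stand for an effect already at smaller amounts and higher numbers for an effect only at larger amounts of compound), compound 1 gives 397 nM, the higher of the two numbers known. Among the compounds with values here, compound 2 gives 0.4 nM, a far lower number, and the gap to compound 1 is well beyond the scatter; the two differ in more than one place, so no single step connects them and nothing is carried from compound 2 into what follows.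

Compound 3, `CCN(Cc1cccs1)C(=O)COc1ccc(CO)cc1`, has not been measured. Relative to compound 1 the change is hydroxymethyl in place of isopropyl on an aromatic carbon, at the position para to a large group on the core of compound 1. Within the data shown here, with no measured neighbour other than compound 1 and no step of this kind available, the working expectation in this assay is a moderate move toward a higher number, a 3.8-fold higher number from compound 1 to compound 3 (0.58 log units; beyond the scatter), beyond the scatter but not by a wide margin.

Compound 3 is accordingly estimated at 1500 nM in this assay, with a range from 400 nM to 6000 nM.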

Compound 3, half-maximal effective concentration: 21900 nM
Compound 3: middle estimate off by 15-fold (1.16 log units), on the low side, outside the stated range (above it).
By their numbers in this assay, from the lowest: compound 2; then compound 1; then compound 3.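

In this assay, going by these compounds alone, hydroxymethyl in place of isopropyl on an aromatic carbon, para to a large group, gives a 55-fold higher number from compound 1 to compound 3 (1.74 log units; beyond the scatter), the first single-place step. The read-out at this position is therefore far from indifferent to the group it carries, at least for this one exchange on the core of compound 1. The change alters several things at once, since isopropyl has 3 heavy atoms and no hydrogen-bond donor or acceptor while hydroxymethyl has 2 heavy atoms, one of them oxygen, and no measurement on hand separates these differences.

On these data alone, whether the oxygen or the size of the group matters more stays open, and a methoxymethyl, an ethyl or a longer alkyl chain at this position would speak to that. Also open, as far as these compounds go, is how an amine or a carboxylic acid would read here, and whether the step carries over to other amide substituents on the shared core.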